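This account rests on a few compounds, and the source may have more. Where it says the series, first, only, none or still open, it means among the compounds named here.

Measured so far in a functional assay on HepG2 cells (Homo sapiens) for antiproliferative activity, read by MTT assay, with a stated time of 48 h; on this read-out lower numbers stand for stronger inhibition and higher numbers for weaker inhibition:
compound 1, `N#CC1=C(N)Oc2c(c3nc4ccccc4nc3c3ccccc23)C12C(=O)N(Cc1cnnn1-c1ccccc1Cl)c1ccccc12`, gives > 50000 nM, which is a limit of the assay and not a number.
compound 2, `CC(=O)Nc1ccc(-n2nncc2CN2C(=O)C3(C(C#N)=C(N)Oc4c3c3nc5ccccc5nc3c3ccccc43)c3ccccc32)cc1`, gives > 50000 nM, likewise a limit of the assay.

Compound 2 therefore stands at the limit of > 50000 nM in this assay, at which 2 of the 2 values shown sit, with no number behind it. For the measured compounds named here, the one measured step, a step that the two limits leave unreadable from compound 1 to compound 2, cannot be read in size because the limit of > 50000 nM in this assay, at which 2 of the 2 values shown sit, covers both of its ends.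

Compound 3, `N#CC1=C(N)Oc2c(c3nc4ccccc4nc3c3ccccc23)C12C(=O)N(Cc1cnnn1-c1ccc(S(N)(=O)=O)cc1)c1ccccc12`, differs from compound 2 by sulfamoyl in place of acetamido on an aromatic carbon. Going by the values given here, no measured step bears on this change: the only step is the one cited above, and it yields no size or direction. The expectation for compound 3 rests on the two limits alone.

Compound 3 is expected to give 70000 nM in this assay, with a range of 20000 nM to 250000 nM, most probably reported again only as a limit. The step this estimate implies, a step that the limit leaves unreadable from compound 2 to compound 3, is an expectation only and carries no readable direction.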

Compound 3, half-maximal inhibitory concentration: 42200 nM
For compound 3 the middle estimate is 1.7-fold (0.22 log units) above the measured one; the measured number falls inside the stated range.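

In this assay, for the compounds shown here, compound 3 gives 42200 nM and is the only one of the three compounds with a number rather than a limit of the assay. This places a floor under two steps, an at least 1.1-fold lower number from compound 2 to compound 3 (0.07 log units; that floor lies within the scatter) for sulfamoyl in place of acetamido and an at least 1.1-fold lower number from compound 1 to compound 3 (0.07 log units; that floor lies within the scatter) for 4-sulfamoylphenyl in place of 2-chlorophenyl, so changes at this aromatic ring now have a partly readable size, although neither floor clears the scatter. Compound 1 and compound 2 both remain limits of the assay, and the step between them cannot be read: the limit of > 50000 nM in this assay, at which 2 of the 3 values shown sit.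

As far as these compounds go, the true size of both steps stays open, and so does whether either exceeds the scatter. A carboxylic acid or an amine in place of sulfamoyl would show whether a number at this position is specific to sulfamoyl.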